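The source may hold more compounds than are shown below. What is called first, only, known or untested is meant among the compounds shown, and "the series" means these compounds.

Measured compounds so far:
- compound 1 `Cc1cc(NCc2ccccn2)n2nc(C)c(-c3ccc(F)cc3)c2n1` gives < 5000 nM in a physicochemical assay for solubility, read by HPLC, using the shake flask method, measured as kinetic solubility, with a stated time of 2 h, at pH 7.4; on this read-out higher numbers stand for higher solubility and lower numbers for lower solubility
- compound 2 `Cc1cc(NCc2ccccn2)n2ncc(-c3ccc(F)cc3)c2n1` gives < 5000 nM in this assay
- compound 3 `Cc1cc(NCc2nccs2)n2nc(C)c(-c3ccccc3)c2n1` gives 108000 nM in this assay

Where compound 2 stands: its value in this assay is a limit of the assay and not a number. The same holds for compound 1, whose value is also a limit. The step from hydrogen in place of methyl on an aromatic carbon, a step that the two limits leave unreadable from compound 1 to compound 2, therefore cannot be read. Among the measured compounds shown here, compound 3 is the only measured compound with a numerical value, and it differs from compound 2 in more than one place, so no single step connects them; its value simply shows that a number within the working range of this assay is reachable. Two of the three values shown sit at the same limit (the limit of < 5000 nM in this assay, at which 2 of the 3 values shown sit).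

The next compound, compound 4 `Cc1cc(NCc2ccccn2)n2ncc(-c3ccc(N(C)C)cc3)c2n1`, differs from compound 2 by dimethylamino in place of fluoro on an aromatic carbon, that is, 4-fluorophenyl to 4-(dimethylamino)phenyl, para to a large group. For the measured compounds named here, none of the measured steps bears on this change: the only single-point step, from compound 1 to compound 2, is unreadable, and no other pair differs in just this position. Going by the values given here, the expectation for compound 4 therefore rests on no measured step and is correspondingly uncertain; the estimated step from compound 2 to compound 4 is an at least 1.6-fold higher number from compound 2 to compound 4 (0.20 log units; that floor lies within the scatter). Compound 4 is expected to give about 8000 nM, within a range of 1500 nM to 40000 nM, in this assay.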

Compound 4, solubility: < 5000 nM
Compound 4: a limit, no number (the forecaster's own chance of this, stated with the estimate: 40%); middle value at least 1.6-fold (0.20 log units) from the limit.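

Compound 4 gives < 5000 nM in this assay, which is a limit of the assay and not a number. Among the compounds shown here, compound 2 also stands at a limit, so no step between compound 2 and compound 4 can be read. Whether dimethylamino in place of fluoro on an aromatic carbon changes the value at all stays open, because the values shown gather at one limit: the limit of < 5000 nM in this assay, at which 3 of the 4 values shown sit.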